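The source may report more compounds than this note shows. Statements on the series, on what has been measured and on what is new or still open speak of the compounds shown alone.

Measured so far:
Compound 1, `CN(C)C(=O)c1cc2cnc(Nc3ccc(C(=O)NCCCCCN=C=S)cc3F)nc2n1C1CCCC1`: 36.1%
Compound 2, `CN(C)C(=O)c1cc2cnc(Nc3ccc(C(=O)NCCCCCCN=C=S)cc3F)nc2n1C1CCCC1`: 29.1%
Compound 3, `CN(C)C(=O)c1cc2cnc(Nc3ccc(NC(=O)CCCN=C=S)cc3)nc2n1C1CCCC1`: 39.7%

All three compounds were tested in a functional assay on NCI-H1299 cells (Homo sapiens) for inhibition, read by CCK-8 assay, with a stated time of 72 h, tested at 1 uM; a higher number here means a stronger effect of the compound at the concentration tested, a lower number a weaker effect. The change from compound 1 to compound 2 is a group of 4 heavy atoms (2 carbon, 1 nitrogen, 1 sulfur; no ring) in place of a group of 3 heavy atoms (1 carbon, 1 nitrogen, 1 sulfur; no ring), on a saturated chain carbon, five bonds along the chain from an amide-type nitrogen, and in this assay it made a number 7 percentage points lower from compound 1 to compound 2 (within the scatter). Compound 3 stands highest of the three; its value lies within the scatter of compound 1, while compound 2 sits beyond the scatter of it. How the core of compound 3 differs from that of compound 1 is not broken down here.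

Compound 4, `CN(C)C(=O)c1cc2cnc(Nc3ccc(NC(=O)CCCCN=C=S)cc3)nc2n1C1CCCC1`, has not yet been measured in this assay. It differs from compound 3 by a group of 4 heavy atoms (2 carbon, 1 nitrogen, 1 sulfur; no ring) in place of a group of 3 heavy atoms (1 carbon, 1 nitrogen, 1 sulfur; no ring), on a saturated chain carbon, three bonds along the chain from a carbonyl carbon. This is the same kind of change as that from compound 1 to compound 2, though the surroundings differ: in the earlier pair the group sits five bonds along the chain from an amide-type nitrogen, whereas here it sits three bonds along the chain from a carbonyl carbon. The expected step is a number 6.7 percentage points lower from compound 3 to compound 4 (within the scatter), since the same kind of change gave a number 7 percentage points lower from compound 1 to compound 2 (within the scatter). Compound 4 is therefore estimated at 33%, with a likely range from 22% to 44%.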

Compound 4, a percentage reported as inhibition, at one concentration (the size of the read-out at that concentration, not a potency): 58.6%
Compound 4: middle estimate off by 25.6 percentage points, on the low side; measured number above the stated range.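

In this assay, putting the group of 4 heavy atoms in place of the group of 3 heavy atoms on the core of compound 3 gave a number 18.9 percentage points higher from compound 3 to compound 4 (beyond the scatter). Set beside the earlier pair, the same change did not carry over from one core to the other with a fixed size or direction: the same change on two cores in this assay, a number 7 percentage points lower (within the scatter) from compound 1 to compound 2 and a number 18.9 percentage points higher (beyond the scatter) from compound 3 to compound 4, 25.9 percentage points apart, beyond the scatter of two such steps This shows that, in these two pairs, the step measured on one core was no guide to the step on the other; it does not show which difference between the cores lies behind the gap, and two pairs set no rule for any other core in the series.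

The compounds shown leave open whether a longer chain on the core of compound 4 would raise the number further or lower it, and whether an amine in place of the group of 4 heavy atoms would keep the effect. Going by these compounds, each number also comes from a single concentration, so it shows only a stronger or weaker effect at that concentration, and how the compounds compare at other concentrations remains open.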